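Swapping isopropoxy for 4-fluorophenyl: notes on compound 3

The source may hold more compounds than are shown below. What is called first, only, known or untested is meant among the compounds shown, and "the series" means these compounds.

Measured in a functional assay on the whole organism for inhibition, with Mus musculus as the target, with a stated time of 60 min; a lower number here means that less compound is needed, a higher number that more compound is needed for the effect:
- compound 1 `C[C@H](Oc1ccc(S(C)(=O)=O)cc1C(=O)N1Cc2ccc(C3CCOCC3)cc2C1)C(F)(F)F`: 0.5 mg/kg
- compound 2 `CC(C)Oc1ccc(S(C)(=O)=O)cc1C(=O)N1Cc2ccc(C3CCOCC3)cc2C1`: 0.5 mg/kg

Level with compound 1, compound 2 stands at 0.5 mg/kg in this assay. For the measured compounds named here, the only measured step, no change at the digits printed from compound 1 to compound 2 (within the scatter), lies within the scatter, but it changes only the group on the oxygen and keeps the oxygen itself.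

Compound 3 `CS(=O)(=O)c1ccc(-c2ccc(F)cc2)c(C(=O)N2Cc3ccc(C4CCOCC4)cc3C2)c1` goes further: 4-fluorophenyl in place of isopropoxy on an aromatic carbon. Here 4-fluorophenyl takes the place of isopropoxy on an aromatic carbon, para to a methylsulfonyl group. Going by the values given here, no measured step removes that oxygen or places a ring there, so the data give no direct size for this change. A moderate loss is expected, held with wide uncertainty. The expected step is a 3.0-fold higher number from compound 2 to compound 3 (0.48 log units; beyond the scatter), towards a higher dose. In this assay the estimate for compound 3 is 1.5 mg/kg, with an expected range of 0.4 mg/kg to 6 mg/kg.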

Compound 3, dose for 50% inhibition in the Mus musculus assay: 0.3 mg/kg
Estimate against measurement, compound 3: 5.0-fold (0.70 log units) above, outside the stated range (below it).
By their numbers in the Mus musculus assay, from the lowest: compounds 3, 1 and 2 (each within the scatter of the next).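

In the Mus musculus assay, the oxygen at this aromatic carbon, para to a methylsulfonyl group, is not required: with 4-fluorophenyl in its place, a six-membered aromatic ring of carbon only, both steps stay within the scatter (a 1.7-fold lower number from compound 2 to compound 3 (0.22 log units; within the scatter)) and (a 1.7-fold lower number from compound 1 to compound 3 (0.22 log units; within the scatter)). For the compounds shown here, the earlier step changed only the group on the oxygen, so this is the first evidence that the position accepts a larger group with no oxygen link. The same change carries a large cost in a physicochemical assay for solubility (a higher number here means a more soluble compound, a lower number a less soluble compound), where compound 2 gives 191 ug/mL and compound 3 gives 15 ug/mL: the measured solubility of compound 2, 191 ug/mL, and of compound 3, 15 ug/mL, a 13-fold lower number (1.10 log units; beyond the scatter).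

As far as these compounds go, it remains open whether a pyridine ring, or a phenyl ring carrying an amine, in place of 4-fluorophenyl would hold the dose in the Mus musculus assay while standing closer to compound 2 in the physicochemical assay. From the compounds shown here alone, the contribution of the fluorine itself to either read-out also remains open.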